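Dropping the chlorine: what the phenyl analogue may tolerate

A few compounds are considered here, and "the series" means these few. Any claim that something is new, unique, unknown or untested is made for them only; others in the source may bear on it.

Of the compounds shown here, three sharing one core have been tested in an ADME assay on HEL cells (Homo sapiens) for cytotoxicity; a lower number here means that less compound is tolerated, a higher number that more compound is tolerated. Compound 1 `C/C(=N\NC(=O)COc1cccc2ccccc12)c1ccc(O)cc1O` gives 74.8 ug/mL. Compound 2 `C/C(=N\NC(=O)COc1cccc2ccccc12)c1ccc([N+](=O)[O-])cc1` reaches only the limit of the assay, > 100 ug/mL, so no number is known for it (the limit of > 100 ug/mL in this assay, at which 1 of the 3 values shown sits). Compound 3 `C/C(=N\NC(=O)COc1cccc2ccccc12)c1ccc(Cl)cc1` gives 7.1 ug/mL, the lowest of the two numbers shown, so it is the least tolerated. The steps of an 11-fold lower number from compound 1 to compound 3 (1.02 log units; beyond the scatter) and an at least 14-fold lower number from compound 2 to compound 3 (1.14 log units; beyond the scatter) both end at compound 3 and both are large.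

Compound 4 `C/C(=N\NC(=O)COc1cccc2ccccc12)c1ccccc1` differs from compound 3 by hydrogen in place of chloro on an aromatic carbon. Neither measured step removes the chloro alone, so they only hint that the chlorine goes with a lower number. A moderate rise is therefore expected, estimated as a 3.5-fold higher number from compound 3 to compound 4 (0.55 log units; beyond the scatter), giving compound 4 an expected value of 25 ug/mL within 8 ug/mL to 80 ug/mL.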

Compound 4, half-maximal cytotoxic concentration: 20 ug/mL
Estimate against measurement, compound 4: 1.3-fold (0.10 log units) above; measured number inside the range.
By their numbers in this assay, from the lowest: compound 3; then compound 4; then compound 1. At a limit, above all of these: compound 2.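

Taken alone, the chlorine change gives a 2.8-fold higher number from compound 3 to compound 4 (0.45 log units; beyond the scatter) in this assay, so the chloro group by itself goes with a lower number at this position. Compound 2 stands at a limit and not at a number, so hydrogen in place of nitro gives only a floor: an at least 5.0-fold lower number from compound 2 to compound 4 (0.69 log units; beyond the scatter). Removing the chlorine does not bring the number up to that of the 2,4-dihydroxyphenyl compound, since phenyl in its place gives a 3.7-fold lower number from compound 1 to compound 4 (0.57 log units; beyond the scatter). Still open is where an amine or a methoxy group at this position would fall among these compounds.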